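Swapping bromo for isopropoxy on the shared core

A few compounds are considered here, and "the series" means these few. Any claim that something is new, unique, unknown or untested is made for them only; others in the source may bear on it.

Within the data shown here, in an assay on isolated protein for displacement of a labelled ligand from 5-hydroxytryptamine receptor 6 (Homo sapiens), read by radioligand binding (a higher number here means a weaker inhibitor, a lower number a stronger inhibitor), compound 2 `CN1CCc2cc(Br)c(NS(=O)(=O)c3ccc(-c4ccc(Cl)cc4)cc3)cc2CC1` gives 50.1 nM, the higher of the two numbers measured so far, which makes it the weaker inhibitor of the pair. Its closest relative is compound 1 `CC(C)c1cc2c(cc1NS(=O)(=O)c1ccc(-c3ccc(Cl)cc3)cc1)CCN(C)CC2`, which in this assay gives 12.6 nM. Among the measured compounds shown here, the single step between them, bromo in place of isopropyl on an aromatic carbon, is a 4.0-fold higher number from compound 1 to compound 2 (0.60 log units; beyond the scatter).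

Compound 3 `CC(C)Oc1cc2c(cc1NS(=O)(=O)c1ccc(-c3ccc(Cl)cc3)cc1)CCN(C)CC2` has not yet been measured. It differs from compound 2 in one place: isopropoxy in place of bromo on an aromatic carbon. For the measured compounds named here, the only measured step that bears on this change is the one from compound 1 to compound 2, where replacing isopropyl with bromo cost a modest amount of binding. Compound 3 puts an isopropyl-type group back at the same position, now attached through an oxygen as isopropoxy. If that earlier loss is largely undone, compound 3 is expected to show a 3.1-fold lower number from compound 2 to compound 3 (0.50 log units; beyond the scatter), landing near where compound 1 stands. The estimate for compound 3 in this assay is therefore 16 nM, with a range from 5 nM to 50 nM.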

Compound 3, inhibition constant: 31.6 nM
Compound 3: the middle estimate sits 2.0-fold (0.30 log units) below what was measured; the measured number falls inside the stated range.
By their numbers in this assay, from the lowest: compound 1; then compounds 3 and 2 (each within the scatter of the next).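

In this assay compound 2 and compound 3 cannot be told apart (a 1.6-fold lower number from compound 2 to compound 3 (0.20 log units; within the scatter)), although bromo is a single heavy atom, isopropoxy has four, and only isopropoxy counts a hydrogen-bond acceptor. Attaching the isopropyl unit through an oxygen does not return the result of compound 1, since isopropoxy in place of isopropyl is a step beyond the scatter (a 2.5-fold higher number from compound 1 to compound 3 (0.40 log units; beyond the scatter)), so among these three groups isopropyl alone stands apart at this position and compound 1 is the strongest inhibitor of the three. Nothing at hand explains why the two groups with carbon chains, so alike in name, end up apart in this way.

Going by these compounds, three groups at one position do not make a trend, so it stays open whether methoxy or a longer chain such as n-butyl would read closer to compound 1 or closer to compound 2 and compound 3. On these data alone, it also stays open how an amine or a carboxylic acid at this position would read in this assay and whether isopropyl would keep its place among such groups.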